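Swapping an aryl ether for an indole in a desaturase inhibitor

This account rests on a few compounds, and the source may have more. Where it says the series, first, only, none or still open, it means among the compounds named here.

Three compounds share one core and differ only in the aromatic group carried on the ether oxygen. Compound 1 `Cc1ccc(OC2CCN(c3ccc(-n4ccnc4)nn3)CC2)cc1` gives 527 nM in an assay on microsomes from liver for inhibition of acyl-CoA desaturase 1 (Rattus norvegicus); a lower number here means a stronger inhibitor, a higher number a weaker inhibitor. Compound 2 `CC(=O)c1ccccc1OC1CCN(c2ccc(-n3ccnc3)nn2)CC1` gives 34 nM, and compound 3 `COc1ccccc1OC1CCN(c2ccc(-n3ccnc3)nn2)CC1` gives 543 nM. Compound 3 thus stands at the highest of the three numbers; against compound 1 the gap is a 1.0-fold higher number from compound 1 to compound 3 (0.01 log units; within the scatter), while a 16-fold higher number from compound 2 to compound 3 (1.20 log units; beyond the scatter) marks the large distance to compound 2.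

The next change makes compound 4 `c1cc(OC2CCN(c3ccc(-n4ccnc4)nn3)CC2)c2cc[nH]c2c1`: 1H-indol-4-yl in place of 2-methoxyphenyl on an oxygen on a saturated carbon. Of the measured steps, the move from compound 1 to compound 3 shows that exchanging one substituted phenyl group for another can leave the number essentially unchanged, whereas the move from compound 2 to compound 3 shows that a single aromatic substituent can shift it greatly. Among the measured compounds shown here, no measured compound carries an indole or a hydrogen-bond donor, so the bearing of these steps is indirect. A step near the scatter is therefore expected, a 1.8-fold lower number from compound 3 to compound 4 (0.26 log units; within the scatter), with wide uncertainty. Compound 4 is estimated at 300 nM, within 60 nM to 1500 nM.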

Compound 4, half-maximal inhibitory concentration: 162 nM
Estimate against measurement, compound 4: 1.9-fold (0.27 log units) above, and the stated range covers the measured number.
By their numbers in this assay, from the lowest: compound 2; then compound 4; then compounds 1 and 3 (each within the scatter of the next).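

In this assay, 1H-indol-4-yl on the ether oxygen gives a clearly stronger inhibitor than either phenyl group without an acetyl, with one step to the 2-methoxyphenyl compound (a 3.4-fold lower number from compound 3 to compound 4 (0.53 log units; beyond the scatter)) and another to the 4-methylphenyl compound (a 3.3-fold lower number from compound 1 to compound 4 (0.51 log units; beyond the scatter)). So this position accepts a group with a second aromatic ring and a hydrogen-bond donor, but that change does not match 2-acetylphenyl (a 4.8-fold higher number from compound 2 to compound 4 (0.68 log units; beyond the scatter)). Nothing available explains these shifts.

The indole differs from the phenyl groups in several ways at once, so these compounds cannot show which difference matters. On these data alone, whether 1-methyl-1H-indol-4-yl, which has a methyl on the indole nitrogen, would keep the gain remains open, as does the effect of an amine or a carboxylic acid on the phenyl ring.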